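The source may report more compounds than this note shows. Statements on the series, on what has been measured and on what is new or still open speak of the compounds shown alone.

The compounds measured so far in an assay on HEK293 cells for inhibition of N-acylethanolamine-hydrolyzing acid amidase (Rattus norvegicus), read by LC-MS, with a stated time of 30 min; a lower number here means a stronger inhibitor, a higher number a weaker inhibitor:
Compound 1 `Cc1ccc(CCCCCC(=O)N2CCOC2=O)cc1C` gives only a limit, > 20000 nM.
Compound 2 `O=C(CCCCCc1cccc(I)c1)N1CCOC1=O` gives 3120 nM.
Compound 3 `O=C(CCCCCc1cccc(CO)c1)N1CCOC1=O` gives only a limit, > 20000 nM.

Among the compounds with values here, compound 2 stands as the only compound with an actual number in this assay; the two other results are limits. Compound 4 `O=C(O)c1cccc(CCCCCC(=O)N2CCOC2=O)c1` differs from compound 2 in one place: carboxy in place of iodo on an aromatic carbon. Within the data shown here, the one measured step that bears on this change is an at least 6.4-fold higher number from compound 2 to compound 3 (0.80 log units; beyond the scatter), in which hydroxymethyl replaced iodo on an aromatic carbon and the result reached (the limit of > 20000 nM in this assay, at which 2 of the 3 values shown sit). Here carboxy enters on an aromatic carbon, and a step of comparable size toward a weaker number is therefore expected in this assay, quite possibly again as a limit. Compound 4 is accordingly expected near 20000 nM, between 5000 nM and 60000 nM, corresponding to a 6.4-fold higher number from compound 2 to compound 4 (0.81 log units; beyond the scatter).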

Compound 4, half-maximal inhibitory concentration: > 20000 nM
Compound 4 was reported as a limit (the forecaster's own chance of this, stated with the estimate: 60%); the middle value sits exactly at the limit.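

In this assay, carboxy in place of iodo on an aromatic carbon gives an at least 6.4-fold higher number from compound 2 to compound 4 (0.80 log units; beyond the scatter), so a second replacement of iodo at this position, meta to a large group, also fails to keep a readable number. Compound 3 and compound 4 both give only limits, and the step between them cannot be read. Iodo remains the only group here with an actual number, and the series now gathers at one ceiling: the limit of > 20000 nM in this assay, at which 3 of the 4 values shown sit.

Going by these compounds, how weak compound 3 and compound 4 really are stays open. So does whether bromo, chloro, methyl or an amine at this position would give a number.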